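Swapping Cyano for Bromo on the Hydroxyphenyl Group

A few compounds are considered here, and "the series" means these few. Any claim that something is new, unique, unknown or untested is made for them only; others in the source may bear on it.

In a physicochemical assay for solubility, measured as kinetic solubility (a higher number here means a more soluble compound, a lower number a less soluble compound), compound 1 `CCC/N=C1\S/C(=C\c2ccc(O)cc2)C(=O)N1c1ccccc1C` gives 79000 nM while compound 2 `CCC/N=C1\S/C(=C\c2ccc(O)c(C#N)c2)C(=O)N1c1ccccc1C` gives 220000 nM as the higher of the two numbers. Compound 3 `CCC/N=C1\S/C(=C\c2ccc(O)c(Br)c2)C(=O)N1c1ccccc1C` has not yet been measured. The change bromo in place of cyano on an aromatic carbon puts bromo in place of cyano on an aromatic carbon, ortho to a hydroxy group and meta to a large group. Among the measured compounds shown here, one measured step bears on it, though only in part: the modest 2.8-fold higher number from compound 1 to compound 2 (0.44 log units; beyond the scatter) came with cyano in place of hydrogen on that same carbon. For the measured compounds named here, no measured compound carries bromo, so the expectation rests on this single step and is uncertain. In this assay a modest move to a lower number is expected, estimated as a 2.9-fold lower number from compound 2 to compound 3 (0.47 log units; beyond the scatter) and of about the size of that step. The estimate for compound 3 is 75000 nM with 28000 nM to 180000 nM as its expected range.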

Compound 3, solubility: 79000 nM
Compound 3: the middle estimate sits 1.1-fold (0.02 log units) below what was measured; the range from low to high includes it.
By their numbers in this assay, from the lowest: compounds 1 and 3 (each within the scatter of the next); then compound 2.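

In this assay the change to bromo gives a 2.8-fold lower number from compound 2 to compound 3 (0.44 log units; beyond the scatter) and so shows that the number reached with cyano does not hold for every group on this aromatic carbon. Set against hydrogen at the same place, bromo gives no change at the digits printed from compound 1 to compound 3 (within the scatter) in the same assay, so a group on this carbon, ortho to a hydroxy group and meta to a large group, need not shift the number at all. No measurement at hand explains why cyano and bromo part here.

Still open, as far as these compounds go, is whether a methoxy group, an amine or a carboxylic acid on this carbon would stand with compound 2 or with compounds 1 and 3. Also open, from the compounds shown here alone, is how cyano and bromo would behave if the hydroxy group were replaced by a methoxy group.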